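A few compounds are considered here, and "the series" means these few. Any claim that something is new, unique, unknown or untested is made for them only; others in the source may bear on it.

Measured so far in a functional assay on U-937 cells (Homo sapiens) for cytotoxicity, read by MTT assay, with a stated time of 24 h; a higher number here means a weaker inhibitor, a lower number a stronger inhibitor:
compound 1 `Cc1ccc(-c2nnc(SCCCN3CCN(c4cccc(Cl)c4)CC3)[nH]2)cc1`: 257000 nM
compound 2 `Clc1ccc(-c2nnc(SCCCN3CCN(c4cccc(Cl)c4)CC3)[nH]2)cc1`: > 300000 nM

Compound 2 stands at the limit of > 300000 nM in this assay, at which 1 of the 2 values shown sits, so its value is a limit of the assay and not a number. Going by the values given here, the one measured step, an at least 1.1-fold higher number from compound 1 to compound 2 (0.06 log units; that floor lies within the scatter), concerns the other aromatic ring and lies within the scatter.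

Compound 3 `Clc1ccc(-c2nnc(SCCCN3CCN(c4ncccn4)CC3)[nH]2)cc1` differs from compound 2 by pyrimidin-2-yl in place of 3-chlorophenyl on an amine nitrogen in a ring. Among the compounds with values here, no measured step touches this amine nitrogen in a ring, so no guide exists for the size or direction of the change. The expected step of a number no higher from compound 2 to compound 3 (the limit leaves the size open) is none beyond the scatter. Compound 3 is therefore estimated at 300000 nM, with a range from 100000 nM to 1000000 nM, and a limit rather than a number is the likelier outcome.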

Compound 3, half-maximal inhibitory concentration: 102000 nM
Compound 3: middle estimate off by 2.9-fold (0.47 log units), on the high side, within the range that was stated.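

Pyrimidin-2-yl in place of 3-chlorophenyl on the amine nitrogen in the ring gives, in this assay, an at least 2.9-fold lower number from compound 2 to compound 3 (0.46 log units; beyond the scatter). Going by these compounds alone, this is the first step beyond the scatter, and it shows that a change at this amine nitrogen can lower the number. Compound 2 carries a limit and not a number, so the true size of the step stays unknown: the limit of > 300000 nM in this assay, at which 1 of the 3 values shown sits.

The compounds shown do not separate the effect of the ring nitrogens from that of losing the chlorine. On these data alone, whether an unsubstituted phenyl or a pyridin-2-yl on this amine nitrogen would lower the number also remains open.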